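Swapping the Pyrazole for a Methoxypyridine

The source may hold more compounds than are shown below. What is called first, only, known or untested is meant among the compounds shown, and "the series" means these compounds.

Of the compounds shown here, three built on one shared core have been tested in an in vitro functional assay on HEK285-7 cells for antagonist activity at prostaglandin D2 receptor 2 (Homo sapiens), read by BRET and beta-arrestin recruitment; a higher number here means a weaker inhibitor, a lower number a stronger inhibitor. Compound 1 `NS(=O)(=O)c1ccc(-c2nc(C(c3ccc(F)cc3)c3ccc(F)cc3)sc2CC(=O)O)cc1` gives only a limit of the assay, > 100000 nM. Compound 2 `NS(=O)(=O)c1cccc(-c2nc(C(c3ccc(F)cc3)c3ccc(F)cc3)sc2CC(=O)O)c1` gives 710 nM in this assay. Compound 3 `O=C(O)Cc1sc(C(c2ccc(F)cc2)c2ccc(F)cc2)nc1-c1cn[nH]c1` gives 220 nM in this assay, the lowest of the two numbers shown; the nearest is compound 2, and the difference is a 3.2-fold lower number from compound 2 to compound 3 (0.51 log units; beyond the scatter).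

Compound 4 `COc1cc(-c2nc(C(c3ccc(F)cc3)c3ccc(F)cc3)sc2CC(=O)O)ccn1` differs from compound 3 by a change at the same position where the earlier changes took place: 2-methoxypyridin-4-yl in place of 1H-pyrazol-4-yl on an aromatic carbon. Within the data shown here, two measured steps bear on this. Moving from a six-membered ring with a sulfamoyl group to the pyrazole gave an at least 450-fold lower number from compound 1 to compound 3 (2.65 log units; beyond the scatter) and a 3.2-fold lower number from compound 2 to compound 3 (0.51 log units; beyond the scatter), so this position is sensitive, and the six-membered rings sit at higher numbers than the pyrazole. The 2-methoxypyridin-4-yl group of compound 4 is again a six-membered ring, so a modestly higher number than that of compound 3 is expected, a 2.7-fold higher number from compound 3 to compound 4 (0.44 log units; beyond the scatter). For compound 4 the estimate in this assay is 600 nM, with a likely range from 120 nM to 4000 nM.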

Compound 4, half-maximal inhibitory concentration: 380 nM
For compound 4 the middle estimate is 1.6-fold (0.20 log units) above the measured one, within the range that was stated.
By their numbers in this assay, from the lowest: compounds 3, 4 and 2 (each within the scatter of the next, the first and the last beyond it). At a limit, above all of these: compound 1.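

A six-membered ring with 0 hydrogen-bond donors can sit at this position with no change beyond the scatter, as a 1.7-fold higher number from compound 3 to compound 4 (0.24 log units; within the scatter) makes plain, so the donor of the pyrazole is not required here. The higher numbers of the earlier six-membered rings therefore do not extend to every such ring, and a 1.9-fold lower number from compound 2 to compound 4 (0.27 log units; within the scatter) shows no separation from the 3-sulfamoylphenyl group either. The 4-sulfamoylphenyl group of compound 1 stands far apart, with an at least 260-fold lower number from compound 1 to compound 4 (2.42 log units; beyond the scatter) resting on a limit of the assay rather than a number: the limit of > 100000 nM in this assay, at which 1 of the 4 values shown sits.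

As far as these compounds go, what the methoxy group itself contributes stays open. A plain pyridin-4-yl ring, or an amine in place of the methoxy group, would separate the effect of the ring from that of its substituent.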